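A Methyl Added to an Inactive Amidine

The source may report more compounds than this note shows. Statements on the series, on what has been measured and on what is new or still open speak of the compounds shown alone.

Of the compounds shown here, two have been measured in a functional assay on Jurkat cells (Homo sapiens) for inhibition, read by MTT assay, with a stated time of 72 h; on this read-out lower numbers stand for stronger inhibition of growth and higher numbers for weaker inhibition of growth. Compound 1 `CN(C)/C=N/c1c(C=O)c(-c2ccccc2)nn1-c1cccc([N+](=O)[O-])c1` gives only the assay limit, > 50000 nM. Compound 2 `CN/C(C)=N/c1cc(-c2ccccc2)nn1-c1ccccc1` likewise reaches only the limit, > 50000 nM. Compound 2 thus stands at the limit of > 50000 nM in this assay, at which 2 of the 2 values shown sit, with no numerical value to place it. Compound 3 `C/C(=N\c1cc(-c2ccccc2)nn1-c1ccccc1)N(C)C` differs from compound 2 by methyl in place of hydrogen on an amine nitrogen. Among the measured compounds shown here, no measured pair shows such a step, so its size cannot be read from the data; the author expects no step beyond the scatter in this assay. The expected step is a step that the limit leaves unreadable from compound 2 to compound 3. Compound 3 is estimated at 60000 nM, within 20000 nM to 200000 nM.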

Compound 3, concentration for 50% growth inhibition: > 50000 nM
Compound 3 was reported as a limit (the forecaster's own chance of this, stated with the estimate: 80%); the middle value lies beyond the limit too.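

No step can be read from compound 2 to compound 3, as both stand only at the assay limit: the limit of > 50000 nM in this assay, at which 3 of the 3 values shown sit. The compounds shown leave open what methyl in place of hydrogen on an amine nitrogen does to growth inhibition.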